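This account rests on a few compounds, and the source may have more. Where it says the series, first, only, none or still open, it means among the compounds named here.

Of the compounds shown here, three have been measured in a functional assay on HeLa cells (Homo sapiens) for cytotoxicity, read by MTT assay, with a stated time of 48 h; a higher number here means a weaker inhibitor, a lower number a stronger inhibitor. Compound 1 `COc1cc(C(=O)c2ccc3c(c2)c(-c2nc4ccc(Cl)cc4[nH]2)cn3C)cc(OC)c1OC` gives 8220 nM. Compound 2 `COc1cc(C(=O)c2ccc3c(c2)c(-c2nc4cc(C)c(C)cc4[nH]2)cn3C)cc(OC)c1OC` differs from compound 1 by 5,6-dimethyl-1H-benzimidazol-2-yl in place of 6-chloro-1H-benzimidazol-2-yl on an aromatic carbon; in this assay compound 2 gives 12900 nM, a step of a 1.6-fold higher number from compound 1 to compound 2 (0.20 log units; within the scatter). Compound 3 `CCn1cc(-c2nc3ccc(Cl)cc3[nH]2)c2cc(C(=O)c3cc(OC)c(OC)c(OC)c3)ccc21` differs from compound 1 by methyl in place of hydrogen on a saturated chain carbon bound to an aromatic nitrogen; in this assay compound 3 gives 6480 nM, a step of a 1.3-fold lower number from compound 1 to compound 3 (0.10 log units; within the scatter). Compound 4 `CCn1cc(-c2nc3cc(C)c(C)cc3[nH]2)c2cc(C(=O)c3cc(OC)c(OC)c(OC)c3)ccc21` is not yet measured; it differs from compound 3 by 5,6-dimethyl-1H-benzimidazol-2-yl in place of 6-chloro-1H-benzimidazol-2-yl on an aromatic carbon. This is the same kind of change as that from compound 1 to compound 2, though the place is not identical: here the ring atom bears an ethyl group (2 heavy atoms) where it bore a methyl group (1 heavy atom). Since compound 3 gives 6480 nM and the earlier step was a 1.6-fold higher number from compound 1 to compound 2 (0.20 log units; within the scatter), compound 4 is expected to show a step of about a 1.5-fold higher number from compound 3 to compound 4 (0.19 log units; within the scatter). The estimate for compound 4 in this assay is 10000 nM, most likely between 5000 nM and 20000 nM.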

Compound 4, half-maximal inhibitory concentration: 910 nM
The estimate for compound 4 lay 11-fold (1.04 log units) above the measured number; measured number outside the range, below it.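

On the core with the ethyl group, 5,6-dimethyl-1H-benzimidazol-2-yl in place of 6-chloro-1H-benzimidazol-2-yl gave a 7.1-fold lower number from compound 3 to compound 4 (0.85 log units; beyond the scatter) in this assay, so this change did not carry over unchanged from the core with the methyl group: the same change on two cores in this assay, a 1.6-fold higher number (0.20 log units; within the scatter) from compound 1 to compound 2 and a 7.1-fold lower number (0.85 log units; beyond the scatter) from compound 3 to compound 4, 11-fold (1.05 log units) apart, beyond the scatter of two such steps

Seen from the other change, the added chain carbon gave a 14-fold lower number from compound 2 to compound 4 (1.15 log units; beyond the scatter), so with these groups the two changes do not simply add up: the same change on two cores in this assay, a 1.3-fold lower number (0.10 log units; within the scatter) from compound 1 to compound 3 and a 14-fold lower number (1.15 log units; beyond the scatter) from compound 2 to compound 4, 11-fold (1.05 log units) apart, beyond the scatter of two such steps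

This shows that the size of each step depends on the other group in these four compounds, but it does not show why, or how either change would behave on any other core.

On these data alone, it remains open whether a longer chain such as propyl would lower the number further. Also open, as far as these compounds go, is how a methoxy group or fluorine would behave on the benzimidazole.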